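Swapping the Aryl on the Ring Nitrogen: Cytotoxicity Outlook

This account rests on a few compounds, and the source may have more. Where it says the series, first, only, none or still open, it means among the compounds named here.

Three compounds that share one core were tested in an ADME assay on RAW264.7 cells (Mus musculus) for cytotoxicity, read by MTT assay, with a stated time of 48 h, tested at 50 uM; a lower number here means less inhibition, a higher number more inhibition at the concentration tested (going by the name of the read-out). Compound 1 `N=C1S/C(=C\c2ccc(OCc3ccccc3)cc2)C(=O)N1c1ccc(Br)cc1` gives 7.83%, the lowest of the three numbers, though only compound 3 stands beyond the scatter from it. Compound 2 `N=C1S/C(=C\c2ccc(OCc3ccccc3)cc2)C(=O)N1c1ccc(Cl)cc1` gives 16.4%; the step of a number 8.6 percentage points higher from compound 1 to compound 2 (within the scatter) lies within the scatter, so these two cannot be told apart. Compound 3 `N=C1S/C(=C\c2ccc(OCc3ccccc3)cc2)C(=O)N1c1cccc([N+](=O)[O-])c1` gives 52.9%; the steps of a number 45.1 percentage points higher from compound 1 to compound 3 (beyond the scatter) and a number 36.5 percentage points higher from compound 2 to compound 3 (beyond the scatter) are both large and beyond the scatter.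

Compound 4 `Cc1cccc(N2C(=N)S/C(=C\c3ccc(OCc4ccccc4)cc3)C2=O)n1` has not yet been measured. It differs from compound 1 in one place: 6-methylpyridin-2-yl in place of 4-bromophenyl on an amide-type nitrogen in a ring. Among the compounds with values here, the steps that bear on this are the two in which 3-nitrophenyl replaced 4-bromophenyl or 4-chlorophenyl on the amide-type nitrogen in the ring, since they show that changing the group on that nitrogen can move the read-out by a large amount. Nothing measured shows what 6-methylpyridin-2-yl does in that place, so the direction is uncertain; a modest rise from the low value of compound 1 is expected, but a number anywhere between the low and the high measured values would not surprise. The step from compound 1 is estimated as a number 12.2 percentage points higher from compound 1 to compound 4 (beyond the scatter). For compound 4 the estimate is 20%, with a range from 5% to 45%.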

Compound 4, a percentage reported as inhibition, at one concentration (the size of the read-out at that concentration, not a potency): 25.1%
The estimate for compound 4 lay 5.1 percentage points below the measured number, and the stated range covers the measured number.
By their numbers in this assay, from the lowest: compounds 1, 2 and 4 (each within the scatter of the next, the first and the last beyond it); then compound 3.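

In this assay the amide-type nitrogen in the ring now carries a third kind of aromatic group, and 6-methylpyridin-2-yl, with a hydrogen-bond acceptor that 4-bromophenyl lacks, gives a number 17.3 percentage points higher from compound 1 to compound 4 (beyond the scatter) and so shows that a change here need not involve a nitro group to pass beyond the scatter. The picture is less simple against the 4-chlorophenyl compound, where the same swap gives a number 8.7 percentage points higher from compound 2 to compound 4 (within the scatter) and leaves the two compounds indistinguishable, while the swap from the nitro compound gives a number 27.8 percentage points lower from compound 3 to compound 4 (beyond the scatter) and leaves compound 3 as the only one beyond the scatter of all the others. Nothing available here explains why these groups at this position give these numbers.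

The compounds shown leave open whether the ring nitrogen or the methyl group of 6-methylpyridin-2-yl accounts for the step from compound 1, as the two enter together. Also open, as far as these compounds go, is how this read-out would respond to an amine or a carboxylic acid on the aromatic ring, or to a plain alkyl chain on the same nitrogen in place of that ring.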